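Terminal aryl exchange in the growth inhibition series

The source may hold more compounds than are shown below. What is called first, only, known or untested is meant among the compounds shown, and "the series" means these compounds.

compound 1 `COc1ccc(-c2ccc(-c3ccc(-c4nc5ccccc5[nH]4)cc3)cc2)cc1` gives 100000 nM
compound 2 `CN(C)c1ccc(-c2ccc(-c3ccc(-c4nc5ccccc5[nH]4)cc3)cc2)cc1` gives 100000 nM

For the measured compounds named here, in a functional assay on HOP-62 cells (Homo sapiens) for inhibition, read by sulforhodamine B assay (a lower number here means a stronger inhibitor of growth, a higher number a weaker inhibitor of growth), compound 2 stands at 100000 nM and level with compound 1, the only other measured compound. The next structure, compound 3 `Clc1cccc(-c2ccc(-c3ccc(-c4nc5ccccc5[nH]4)cc3)cc2)c1`, has 3-chlorophenyl in place of 4-(dimethylamino)phenyl on an aromatic carbon, para to a large group, and the change counts as 3-chlorophenyl in place of 4-(dimethylamino)phenyl on an aromatic carbon in full.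

Going by the values given here, only one measured step bears on this. It shows no change at the digits printed from compound 1 to compound 2 (within the scatter) when dimethylamino replaces methoxy on an aromatic carbon. That step exchanged a smaller group than the one exchanged here, and neither measured compound carries chlorine, so the guidance is indirect. Among the compounds with values here, the data also show no compound with stronger inhibition of growth, so how far values can fall is unknown.

No step beyond the scatter is expected in this assay, the estimate being a 1.4-fold lower number from compound 2 to compound 3 (0.15 log units; within the scatter), with any real move more likely toward stronger inhibition. For compound 3 the estimated value is 70000 nM, with 20000 nM to 100000 nM as the expected range.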

Compound 3, concentration for 50% growth inhibition: 100000 nM
Compound 3: the middle estimate sits 1.4-fold (0.15 log units) below what was measured, and the stated range covers the measured number.
By their numbers in this assay, from the lowest: compounds 1, 2 and 3 (each within the scatter of the next).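

In this assay the exchange of the whole terminal aryl group, a wider change than the earlier swap of one substituent, gives no change at the digits printed from compound 2 to compound 3 (within the scatter) and, measured against the methoxy compound, no change at the digits printed from compound 1 to compound 3 (within the scatter) as well. For the compounds shown here, this place, on an aromatic carbon of a six-membered aromatic ring of carbon only and para to a large group, has therefore now carried 4-methoxyphenyl, 4-(dimethylamino)phenyl and 3-chlorophenyl with one printed number for all three, and the first chlorine-bearing group fits that picture. The entering 3-chlorophenyl has 0 hydrogen-bond acceptors where the leaving 4-(dimethylamino)phenyl has 1, and that difference in count comes with no move in the number; nothing further is available that would explain this result.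

With all three compounds at one value, the series does not yet show whether any group at this place can move the number at all. A carboxylic acid or a primary amine on the terminal ring, or a pyridine ring in place of the terminal phenyl, would test that, and the same question stands open for changes made to the shared core.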